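The source may report more compounds than this note shows. Statements on the series, on what has been measured and on what is new or still open speak of the compounds shown alone.

Working notes on an ADME assay on the whole organism (Macaca fascicularis) for metabolic stability (on this read-out higher numbers stand for a longer-lived compound and lower numbers for a shorter-lived compound), for this series. Compound 1 `CCc1sc(N(CC2CC2)[C@H](C)c2ccc(-c3cc(C)ccc3-c3nc(=O)o[nH]3)cc2)nc1C(=O)NS(=O)(=O)C1CC1` gives 3 h in this assay. Compound 2 `Cc1ccc(-c2nc(=O)o[nH]2)c(-c2ccc([C@@H](C)N(CC3CC3)c3nc(C(=O)NS(=O)(=O)C4CC4)c(C(C)C)s3)cc2)c1` gives 2.4 h in this assay, and compound 3 `COCCc1sc(N(CC2CC2)[C@H](C)c2ccc(-c3cc(C)ccc3-c3nc(=O)o[nH]3)cc2)nc1C(=O)NS(=O)(=O)C1CC1` gives 2.6 h in this assay. Compound 1 carries the top number of the three, yet the step of a 1.3-fold lower number from compound 1 to compound 2 (0.10 log units; within the scatter) and the step of a 1.2-fold lower number from compound 1 to compound 3 (0.06 log units; within the scatter) both lie within the scatter, as does the step of a 1.1-fold higher number from compound 2 to compound 3 (0.03 log units; within the scatter), so the three compounds are not separated in this assay.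

Compound 4 `Cc1ccc(-c2nc(=O)o[nH]2)c(-c2ccc([C@@H](C)N(CC3CC3)c3nc(C(=O)NS(=O)(=O)C4CC4)c(C)s3)cc2)c1` is not yet measured. It differs from compound 1 by hydrogen in place of methyl on a saturated chain carbon bound to an aromatic carbon. The step from compound 1 to compound 2 bears on it most directly, being a change at the same place, methyl in place of hydrogen on a saturated chain carbon bound to an aromatic carbon, and it read a 1.3-fold lower number from compound 1 to compound 2 (0.10 log units; within the scatter). The step of a 1.2-fold lower number from compound 1 to compound 3 (0.06 log units; within the scatter), on the same chain, also left the number where it was. Since no change at this place has moved this assay beyond the scatter, the step expected here, a 1.1-fold higher number from compound 1 to compound 4 (0.03 log units; within the scatter), is none beyond the scatter. Compound 4 is therefore estimated at 3.2 h, with a range from 1.7 h to 6 h.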

Compound 4, half-life: 2.1 h
Compound 4: middle estimate off by 1.5-fold (0.18 log units), on the high side; the range from low to high includes it.
By their numbers in this assay, from the lowest: compounds 4, 2, 3 and 1 (each within the scatter of the next).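

At the aromatic carbon that carries this chain, shortening ethyl to methyl does not separate the compounds in this assay, as a 1.4-fold lower number from compound 1 to compound 4 (0.15 log units; within the scatter) still lies within the scatter. Compound 4 also stays unseparated from the two larger groups, with a 1.2-fold lower number from compound 3 to compound 4 (0.09 log units; within the scatter) and a 1.1-fold lower number from compound 2 to compound 4 (0.06 log units; within the scatter) both within the scatter, so methyl, ethyl, isopropyl and 2-methoxyethyl at this place all read alike across these four compounds. Nothing measured on these compounds speaks to what lies behind these numbers.

Whether any group at this place can move the half-life beyond the scatter remains open, since an amine, a carboxylic acid or a phenyl group does not appear among the compounds shown. All four compounds also share the same core, so whether this flat reading holds on a different core is open too.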